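This account rests on a few compounds, and the source may have more. Where it says the series, first, only, none or still open, it means among the compounds named here.

Going by the values given here, compound 2, with the structure `O=C(O)c1ccc2noc(-c3ccc(NC(=O)C4CCCC4)cc3)c2c1`, gives 190 nM in an assay for inhibition of inositol hexakisphosphate kinase 2 (Homo sapiens), read by colorimetric assay, coupled enzyme assay and malachite green, with a stated time of 120 min, in the presence of a further agent that is not named here (on this read-out higher numbers stand for weaker inhibition and lower numbers for stronger inhibition), and this is the higher of the two numbers so far recorded, though only within the scatter of the other one. The other measured compound is compound 1, with the structure `O=C(O)c1ccc2noc(-c3ccc(-c4ccncc4)cc3)c2c1`, which in this assay gives 150 nM. Among the compounds with values here, the single measured step, a 1.3-fold higher number from compound 1 to compound 2 (0.10 log units; within the scatter), replaced pyridin-4-yl by (cyclopentylcarbonyl)amino on an aromatic carbon and changed the number by an amount that sits inside the usual scatter.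

Compound 3, with the structure `O=C(O)c1ccc2noc(-c3ccc(NC(=O)c4ccccc4)cc3)c2c1`, differs from compound 2 by phenyl in place of cyclopentyl on a carbonyl carbon. Within the data shown here, no measured pair swaps phenyl for cyclopentyl on a carbonyl carbon, so the only step that bears on this change is the one from compound 1 to compound 2, which was small and touched the same substituent at an earlier stage of its build-up. On that basis the step is expected to be modest, with no clear direction, and the number for compound 3 is estimated at 180 nM, within a range from 70 nM to 450 nM, meaning an expected step of a 1.1-fold lower number from compound 2 to compound 3 (0.02 log units; within the scatter).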

Compound 3, half-maximal inhibitory concentration: 580 nM
For compound 3 the middle estimate is 3.2-fold (0.51 log units) below the measured one; measured number outside the range, above it.
By their numbers in this assay, from the lowest: compounds 1 and 2 (each within the scatter of the next); then compound 3.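

In this assay the group on the carbonyl carbon proves not to be interchangeable: with the amide-type nitrogen kept, phenyl in place of cyclopentyl gives a step beyond the scatter, towards weaker inhibition (a 3.1-fold higher number from compound 2 to compound 3 (0.48 log units; beyond the scatter)). The benzamido group also stands beyond the scatter from pyridin-4-yl (a 3.9-fold higher number from compound 1 to compound 3 (0.59 log units; beyond the scatter)), whereas (cyclopentylcarbonyl)amino had stayed within it, so an amide at this aromatic carbon does not by itself keep the number level with that of compound 1, and the two amides differ only in what sits on the carbonyl carbon. Nothing available explains why the six-membered aromatic ring of carbon reads weaker here than the five-membered non-aromatic ring of carbon.

From the compounds shown here alone, it remains open whether the higher number goes with the aromatic character of the ring or with its size, a question that a cyclohexyl group on the same carbonyl carbon would help to separate. Going by these compounds, it is equally open how a pyridine ring, or a phenyl ring carrying an amine, would read at that carbon, and whether any group there could give stronger inhibition than cyclopentyl.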